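A 2-Chlorobenzyl Group in Place of Hydrogen

The compounds below may be only part of what the source reports. "The series", "measured", "known", "first", "only" and "open" are said of these compounds alone.

Compound 1 `Cc1ccc(-c2nc(N)c3ccsc3n2)o1` is the parent of this small set. Among the compounds with values here, in a functional assay on CHO-K1 cells for antagonist activity at adenosine receptor A1 (Homo sapiens), read by a beta-galactosidase reporter and cAMP accumulation, with stated times of 15 min and 6 h (a higher number here means a weaker inhibitor, a lower number a stronger inhibitor), compound 1 gives 493 nM, the lowest of the two numbers measured so far, though its nearest neighbour sits within the scatter. Compound 2 `Cc1ccc(-c2nc(N)c3cc(-c4ccccc4)sc3n2)o1` carries phenyl in place of hydrogen on an aromatic carbon of the shared core; in this assay compound 2 gives 520 nM. The step of a 1.1-fold higher number from compound 1 to compound 2 (0.02 log units; within the scatter) shows that adding a phenyl group at this aromatic carbon left the number essentially unchanged.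

Compound 3 `Cc1ccc(-c2nc(N)c3cc(Cc4ccccc4Cl)sc3n2)o1` differs from compound 1 as follows: 2-chlorobenzyl in place of hydrogen on an aromatic carbon. Within the data shown here, the only measured step that bears on this change is a 1.1-fold higher number from compound 1 to compound 2 (0.02 log units; within the scatter), in which a ring-containing group entered at the same aromatic carbon and the number stayed within the scatter. Among the measured compounds shown here, the 2-chlorobenzyl group is related to, but not the same as, phenyl, so the single precedent is a guide rather than a guarantee. I therefore expect no step beyond the scatter, an estimated change of a 1.0-fold higher number from compound 1 to compound 3 (0.01 log units; within the scatter). For compound 3 the estimated value in this assay is 500 nM, with an expected range from 200 nM to 1300 nM.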

Compound 3, inhibition constant: 26.1 nM
For compound 3 the middle estimate is 19-fold (1.28 log units) above the measured one, and the stated range ends above it.
By their numbers in this assay, from the lowest: compound 3; then compounds 1 and 2 (each within the scatter of the next).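

This aromatic carbon next to the ring sulfur is not indifferent to what it carries: this assay shows a 19-fold lower number from compound 1 to compound 3 (1.28 log units; beyond the scatter), although phenyl at the same carbon had left the number within the scatter of the parent. The two groups can also be set directly against each other, and that comparison gives a 20-fold lower number from compound 2 to compound 3 (1.30 log units; beyond the scatter), so the presence of a six-membered aromatic ring at this carbon is not enough to predict the result, and the particular group that enters matters a great deal. Nothing available here explains why 2-chlorobenzyl and phenyl behave so differently.

The compounds shown leave open which part of 2-chlorobenzyl goes with the lower number, the carbon that links the ring to the core or the chlorine, and plain benzyl and 2-chlorophenyl at this carbon would help to separate the two. They also leave open whether a group with no ring at all, such as a longer alkyl chain or an amine, could give a similar step at this carbon.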